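A few compounds are considered here, and "the series" means these few. Any claim that something is new, unique, unknown or untested is made for them only; others in the source may bear on it.

Series notes. Compound 1 `O=c1c(Cl)c(CSC(=S)N2CCOCC2)oc2ccccc12` is the weaker of the two measured compounds: in a functional assay on HEp-2 cells (Homo sapiens) for antiproliferative activity, read by MTT assay, with a stated time of 72 h (a higher number here means a weaker inhibitor, a lower number a stronger inhibitor), compound 1 gives 9000 nM, the highest of the two numbers, while compound 2 `O=c1c(CSC(=S)N2CCOCC2)coc2cc(Cl)ccc12` gives 900 nM in this assay. Compound 3 `CC(C)N(C(=S)SCc1oc2ccccc2c(=O)c1Cl)C(C)C` is not yet measured. It differs from compound 1 in one place (diisopropylamino in place of morpholin-4-yl on a thiocarbonyl carbon). Among the measured compounds shown here, no measured pair shows this change, so no step can be read off for it; the expected step from compound 1 to compound 3 is small, a 1.3-fold lower number from compound 1 to compound 3 (0.11 log units; within the scatter), not beyond the scatter in either direction. For compound 3 the estimate in this assay is 7000 nM, with a range from 2500 nM to 20000 nM.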

Compound 3, half-maximal inhibitory concentration: 20000 nM
For compound 3 the middle estimate is 2.9-fold (0.46 log units) below the measured one; the measured number falls inside the stated range.
By their numbers in this assay, from the lowest: compound 2; then compound 1; then compound 3.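

The amine on the thiocarbonyl carbon turns out not to be a silent part of the series: in this assay diisopropylamino in place of morpholin-4-yl gives a 2.2-fold higher number from compound 1 to compound 3 (0.35 log units; beyond the scatter), a modest loss on the core of compound 1. Among the compounds shown here, this is the first reading of this position, and it favours the morpholin-4-yl ring over the open diisopropylamino group in this single pair. Nothing measured bears on the reason for this step.

Open, going by these compounds, is whether the ring, its oxygen or the branched chains govern the step; piperidin-1-yl or dimethylamino at this place could separate them. Also open, on these data alone, is whether the step carries over to the core of compound 2.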